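The source may report more compounds than this note shows. Statements on the series, on what has been measured and on what is new or still open speak of the compounds shown alone.

Measured in a functional assay on CLL cells (Homo sapiens) for cytotoxicity, read by MTT assay, with a stated time of 48 h; a lower number here means that less compound is needed, a higher number that more compound is needed for the effect:
compound 1 `C=C(CC)C(=O)c1ccc(OCC(=O)Nc2cccc(C(=O)O)c2)c(Cl)c1Cl` gives 20600 nM
compound 2 `C=C(CC)C(=O)c1ccc(OCC(=O)Nc2ccc(O)c(Cl)c2)c(Cl)c1Cl` gives 5500 nM
compound 3 `C=C(CC)C(=O)c1ccc(OCC(=O)NCC2CCC(C(=O)O)CC2)c(Cl)c1Cl` gives 8000 nM

Compound 3 and compound 2 lie within the usual scatter of each other, so these numbers cannot tell them apart. Compound 1 has a clearly higher number than both.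

Compound 4 `C=C(CC)C(=O)c1ccc(OCC(=O)NCCO)c(Cl)c1Cl` has not been measured yet. Starting from compound 3, it carries hydroxymethyl in place of 4-carboxycyclohexyl on a saturated chain carbon bound to an amide-type nitrogen. Among the compounds with values here, no measured step makes this exact change. The closest guide is a 3.7-fold lower number from compound 1 to compound 2 (0.57 log units; beyond the scatter), a modest step in which 3-chloro-4-hydroxyphenyl replaced 3-carboxyphenyl, so a carboxy group was lost there too. The measured values do not tie that group to a high number, however. Compound 3 keeps a carboxy group at 8000 nM, and compound 2 has none at 5500 nM, yet the two sit within the scatter. Compound 1 alone pairs a carboxy group with a clearly higher number. Nothing measured shows how so small a group behaves here, so no clear direction can be expected. The expected change is a 1.1-fold lower number from compound 3 to compound 4 (0.06 log units; within the scatter), which would stay within the scatter. For compound 4 the estimated value is 7000 nM, with an expected range from 2800 nM to 18000 nM.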

Compound 4, half-maximal effective concentration: > 25000 nM
Compound 4: a limit, no number; the forecaster's own chance of this, stated with the estimate: 3%; middle value at least 3.5-fold (0.55 log units) away from the limit.
By their numbers in this assay, from the lowest: compounds 2 and 3 (each within the scatter of the next); then compound 1. At a limit, above all of these: compound 4.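

In this assay, compound 4 gives a limit and not a number: the limit of > 25000 nM in this assay, at which 1 of the 4 values shown sits. Even so, the limit allows three steps to be read: hydroxymethyl in place of 4-carboxycyclohexyl gives an at least 3.1-fold higher number from compound 3 to compound 4 (0.49 log units; beyond the scatter), 2-hydroxyethyl in place of 3-chloro-4-hydroxyphenyl gives an at least 4.5-fold higher number from compound 2 to compound 4 (0.65 log units; beyond the scatter), and 2-hydroxyethyl in place of 3-carboxyphenyl gives an at least 1.2-fold higher number from compound 1 to compound 4 (0.08 log units; that floor lies within the scatter). The earlier compounds shown here all carried a ring on this side of the amide, so only now is it clear that cutting this group back to a short chain without a ring can cost much of the effect, although compound 1 shows that having a ring does not by itself give the lowest numbers.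

The compounds shown do not separate the loss of the ring from the loss of the atoms in general. A longer chain ending in a hydroxyl group, an amine on the same short chain, or a plain cyclohexyl group with no carboxylic acid would help to tell which of these matters at this position.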